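Cytotoxicity notes: from compound 3 to compound 4

A few compounds are considered here, and "the series" means these few. Any claim that something is new, unique, unknown or untested is made for them only; others in the source may bear on it.

Values so far in an ADME assay on NCM460 cells (Homo sapiens) for cytotoxicity, read by CCK-8 assay, with a stated time of 48 h; a higher number here means a weaker inhibitor, a lower number a stronger inhibitor

compound 1 (`COc1ccc(/C=C\c2cc(OC)c(OC)c(OC)c2)cc1OCc1ccc(CN2CCCC[C@@H]2C(=O)O)cc1`) gives > 50000 nM
compound 2 (`COc1ccc(/C=C\c2cc(OC)c(OC)c(OC)c2)cc1OCc1ccc(CN2CC[C@H](C(=O)O)C2)cc1`) gives > 50000 nM
compound 3 (`COc1ccc(/C=C\c2cc(OC)c(OC)c(OC)c2)cc1OCc1ccc(CN2CC[C@@H](O)C2)cc1`) gives 53000 nM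

In this assay, going by the values given here, compound 3 holds the only true number (53000 nM). Compound 1 stands at a limit (> 50000 nM) and not at a number. Compound 2 also stands at a limit (> 50000 nM) and not at a number. The series therefore rests largely on the limit of > 50000 nM in this assay, at which 2 of the 3 values shown sit, and offers little graded information.

Compound 4 (`COc1ccc(/C=C\c2cc(OC)c(OC)c(OC)c2)cc1OCc1ccc(CN[C@H](C(=O)O)[C@@H](C)O)cc1`) is the next case. It has (1-carboxy-2-hydroxypropyl)amino in place of 3-hydroxypyrrolidin-1-yl on a saturated chain carbon bound to an aromatic carbon. The measured steps nearest to this change are a step that the limit leaves unreadable from compound 1 to compound 3 and a step that the limit leaves unreadable from compound 2 to compound 3 and neither gives a size to carry over.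

No step beyond the scatter is expected, and a report of only a limit is likely, as compound 2 (> 50000 nM) also carries a carboxy group and stands at a limit. The expected step is a 1.1-fold higher number from compound 3 to compound 4 (0.05 log units; within the scatter) in this assay and no firm direction is expected. For compound 4 the estimated value is 60000 nM (expected range 30000 nM to 110000 nM).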

Compound 4, half-maximal inhibitory concentration: > 50000 nM
Compound 4 was reported as a limit (the forecaster's own chance of this, stated with the estimate: 65%); the middle value does not contradict the limit.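

Compound 4 stands at > 50000 nM as a limit and not a number (this assay), so the steps from compound 3, compound 2 and compound 1 to compound 4 cannot be read. The compounds shown leave open whether these side chains on the shared core differ at all in this assay and what true values lie behind the limits of compound 1, compound 2 and compound 4.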